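A few compounds are considered here, and "the series" means these few. Any claim that something is new, unique, unknown or untested is made for them only; others in the source may bear on it.

Measured compounds:
- compound 1, `COc1cc(C(=O)Nc2nn[nH]n2)nc(-c2ccccc2)c1`, gives 100%
- compound 2, `CCc1cc(C(=O)Nc2nn[nH]n2)nc(-c2ccccc2)c1`, gives 85%
- compound 3, `CCCCc1cc(C(=O)Nc2nn[nH]n2)nc(-c2ccccc2)c1`, gives 100%

In a functional assay on the whole organism for inhibition, with Rattus norvegicus as the target, at a dose of 10 mg/kg by the oral route (a higher number here means a stronger effect of the compound at the dose given, a lower number a weaker effect), compound 3 stands together with compound 1 at the top of the three numbers: no change at the digits printed from compound 1 to compound 3 (within the scatter), while a number 15 percentage points higher from compound 2 to compound 3 (beyond the scatter). Compound 4, `CCCCc1cc(C(=O)Nc2nn[nH]n2)nc(-c2cccc(C)c2)c1`, differs from compound 3 by methyl in place of hydrogen on an aromatic carbon, read one bond further out as phenyl to 3-methylphenyl. None of the three measured steps bears on this change: each of them alters the group on the other ring of the shared core, and the phenyl ring is untouched throughout. With compound 3 already at the full read-out, the step is expected to be a number 8 percentage points lower from compound 3 to compound 4 (within the scatter). Compound 4 is therefore estimated at 92%, in a range from 65% to 100%.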

Compound 4, a percentage reported as inhibition, in the whole organism at one dose (the size of the read-out at that dose, not a potency): 100%
Estimate against measurement, compound 4: 8 percentage points below; measured number inside the range.
By their numbers in this assay, from the lowest: compound 2; then compounds 1, 3 and 4 (each within the scatter of the next).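

In this assay, the only change shown on the phenyl ring, methyl in place of hydrogen on an aromatic carbon, gives no change at the digits printed from compound 3 to compound 4 (within the scatter) and is therefore tolerated at this dose. Both compounds sit at the full read-out, so any gain from the methyl could not show, and a single dose gives no potency to compare. Nothing measured here explains the result. As far as these compounds go, whether an amine or a carboxylic acid at this place on the ring would also keep the full read-out remains open.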